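Replacing a chlorophenyl by an aminophenyl on two cores

The source may hold more compounds than are shown below. What is called first, only, known or untested is meant among the compounds shown, and "the series" means these compounds.

Compound 1 `O=C(N/N=C/C1=C(Cl)c2ccccc2CCC1)c1cccc(Cl)c1` and compound 2 `Nc1ccccc1C(=O)N/N=C/C1=C(Cl)c2ccccc2CCC1` share one core, while compound 3 `Cc1cc2c(cc1C)C(Cl)=C(/C=N/NC(=O)c1cccc(Cl)c1)CCC2` and compound 4 `Cc1cc2c(cc1C)C(Cl)=C(/C=N/NC(=O)c1ccccc1N)CCC2` share another; the difference between the two cores is not broken down here. In a functional assay on IMR-32 cells (Homo sapiens) for inhibition, read by sulforhodamine B assay, with a stated time of 48 h (on this read-out lower numbers stand for stronger inhibition of growth and higher numbers for weaker inhibition of growth), compound 1 gives 27300 nM. Compound 2 gives 51000 nM in this assay. The change between them, (2-aminophenyl in place of 3-chlorophenyl on a carbonyl carbon), produced a 1.9-fold higher number from compound 1 to compound 2 (0.27 log units; within the scatter). For compound 3 this assay reports only a limit, > 100000 nM. Compound 4 carries the same change, (2-aminophenyl in place of 3-chlorophenyl on a carbonyl carbon), on the same place. Because compound 3 sits at the limit of > 100000 nM in this assay, at which 1 of the 3 values shown sits, and because a 1.9-fold higher number from compound 1 to compound 2 (0.27 log units; within the scatter) stayed within the scatter, compound 4 is expected to show a step that the limit leaves unreadable from compound 3 to compound 4. Compound 4 is accordingly estimated at 150000 nM in this assay, most likely reported again only as a limit.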

Compound 4, concentration for 50% growth inhibition: 36300 nM
Compound 4: the middle estimate sits 4.1-fold (0.62 log units) above what was measured, outside the stated range (below it).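

In this assay, the change to 2-aminophenyl in place of 3-chlorophenyl on a carbonyl carbon gave an at least 2.7-fold lower number from compound 3 to compound 4 (0.44 log units; beyond the scatter), so the change did not carry over with the same outcome from one core to the other: the same change on two cores in this assay, a 1.9-fold higher number (0.27 log units; within the scatter) from compound 1 to compound 2 and an at least 2.7-fold lower number (0.44 log units; beyond the scatter) from compound 3 to compound 4, at least 5.1-fold (0.71 log units) apart, beyond the scatter of two such steps. Going by these compounds, the value of compound 3 is only a limit, so the true size of this step stays unknown: the limit of > 100000 nM in this assay, at which 1 of the 4 values shown sits. These two pairs show that the outcome of the change depends on the core, but they do not show which part of the core is responsible, or why.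

The compounds shown leave open how a methoxy group or a carboxylic acid in place of the amine on the phenyl ring would behave on either core. They also leave open what the same change would do on any third core.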